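Thiosemicarbazones: halogenated aryl swap on the hydrazone carbon

The compounds below may be only part of what the source reports. "The series", "measured", "known", "first", "only" and "open" are said of these compounds alone.

Compound 3 `CC1=CC[C@H](C(C)(C)NC(=S)N/N=C/c2ccc(F)cc2)CC1` stands at the limit of a functional assay on NCI-H460 cells (Homo sapiens) for inhibition, read by sulforhodamine B assay, with a stated time of 48 h; a higher number here means a weaker inhibitor of growth, a lower number a stronger inhibitor of growth: in this assay compound 3 gives > 100000 nM, which is a limit of the assay and not a number. Compound 2 `CC1=CC[C@H](C(C)(C)NC(=S)N/N=C/c2ccc(O)cc2)CC1` stands at the same limit; in this assay compound 2 gives > 100000 nM. Only compound 1 `COc1ccc(/C=N/NC(=S)NC(C)(C)[C@H]2CC=C(C)CC2)cc1` returns a number, and in this assay compound 1 gives 47800 nM. The limit itself is the relevant fact here: the limit of > 100000 nM in this assay, at which 2 of the 3 values shown sit.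

Compound 4 `CC1=CC[C@H](C(C)(C)NC(=S)N/N=C/c2ccccc2Cl)CC1` differs from compound 3 by 2-chlorophenyl in place of 4-fluorophenyl on a carbon with a double bond to nitrogen. The measured steps that touch the same aryl ring are an at least 2.0-fold higher number from compound 1 to compound 3 (0.32 log units; beyond the scatter) and an at least 2.0-fold higher number from compound 1 to compound 2 (0.32 log units; beyond the scatter), while a step that the two limits leave unreadable from compound 2 to compound 3. Within the data shown here, none of these steps exchanges one halogen-bearing phenyl for another, so the change to compound 4 has no direct counterpart among the measured compounds. With compound 3 at the limit, a weakening cannot be read at all, and only a clear return to a number would show a strengthening. The expectation for compound 4 is therefore that it remains at or near the limit, the step of a number no higher from compound 3 to compound 4 (the limit leaves the size open) being expected as essentially none. Compound 4 is estimated at 100000 nM, within a range of 30000 nM to 300000 nM.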

Compound 4, concentration for total growth inhibition: 81000 nM
Estimate against measurement, compound 4: 1.2-fold (0.09 log units) above, and the stated range covers the measured number.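

In this assay, 2-chlorophenyl on the carbon with a double bond to nitrogen gives a readable value, so compound 1 no longer stands alone among the compounds with a number: compound 4 gives 81000 nM. The steps from the two compounds at the limit are an at least 1.2-fold lower number from compound 3 to compound 4 (0.09 log units; that floor lies within the scatter) and an at least 1.2-fold lower number from compound 2 to compound 4 (0.09 log units; that floor lies within the scatter), so the appearance of a number at this position does not establish a real gain in growth inhibition. Between the two compounds with numbers the step is a 1.7-fold higher number from compound 1 to compound 4 (0.23 log units; within the scatter), so 2-chlorophenyl and 4-methoxyphenyl cannot be ordered at this position, and the series still sits high in the range of the assay, with some of its readings at a limit and not at a number: the limit of > 100000 nM in this assay, at which 2 of the 4 values shown sit.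

Relative to compound 3, the halogen and its place on the aryl ring change together in compound 4, and the compounds shown do not separate these two changes. From the compounds shown here alone, whether an amine or a carboxylic acid on the aryl ring would give a value beyond the scatter from compound 1 also remains open.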